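From Methyl-Oxadiazolyl to Methylcarbamoyl at the Assay Limit

The compounds below may be only part of what the source reports. "The series", "measured", "known", "first", "only" and "open" are said of these compounds alone.

Of the compounds shown here, two have been measured so far, and neither gives an exact number. In a physicochemical assay for solubility, measured as kinetic solubility (on this read-out lower numbers stand for lower solubility and higher numbers for higher solubility), compound 1, `O=C1CCCN1Cc1n[nH]c(-c2ncc3cccnc3c2O)n1`, gives > 250000 nM, which is a limit of the assay and not a number. Compound 2, `COc1ccccc1-c1nc(-c2nnc(C)o2)c(O)c2ncccc12`, also reaches only a limit, > 250000 nM. Compound 2 therefore stands with compound 1 at the limit of > 250000 nM in this assay, at which 2 of the 2 values shown sit.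

Compound 3, `CNC(=O)c1nc(-c2ccccc2OC)c2cccnc2c1O`, carries methylcarbamoyl in place of 5-methyl-1,3,4-oxadiazol-2-yl on an aromatic carbon, ortho to a hydroxy group: methylcarbamoyl in place of 5-methyl-1,3,4-oxadiazol-2-yl on an aromatic carbon. Among the compounds with values here, no measured pair differs in one place, so no measured step gives a size for this change. The expected move is small and, if anything, downward, and the estimated at least 1.2-fold lower number from compound 2 to compound 3 (0.09 log units; that floor lies within the scatter) stays within the usual scatter. Compound 3 is expected to give 200000 nM in this assay, with an estimated range of 70000 nM to 250000 nM.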

Compound 3, solubility: 219000 nM
For compound 3 the middle estimate is 1.1-fold (0.04 log units) below the measured one; low and high end bracket the measured number.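

At this position, on an aromatic carbon next to the ring nitrogen, methylcarbamoyl in place of 5-methyl-1,3,4-oxadiazol-2-yl gives an at least 1.1-fold lower number from compound 2 to compound 3 (0.05 log units; that floor lies within the scatter) in this assay and brings the first exact number. The step is only a floor: the value of compound 2 is a limit of the assay, and the floor lies within the usual scatter, so no real drop is shown. Compound 3 is thus the only compound shown with an exact number, while the other two stop at the top of the range: (the limit of > 250000 nM in this assay, at which 2 of the 3 values shown sit).

Going by these compounds, how far compound 2 actually lies from compound 3 stays open. Also open, on these data alone, is how a carboxylic acid or a longer chain such as ethylcarbamoyl at this same place would read in this assay.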